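Methylsulfanyl for tert-butyl on a stilbene core

The source may report more compounds than this note shows. Statements on the series, on what has been measured and on what is new or still open speak of the compounds shown alone.

Compound 1, `COc1cc(/C=C/c2ccc(C(C)(C)C)cc2)cc(OC)c1OC`, in a functional assay on A549 cells (Homo sapiens) for cytotoxicity (on this read-out lower numbers stand for an effect already at smaller amounts and higher numbers for an effect only at larger amounts of compound), gives > 25 uM.
Compound 2, `COC(=O)/C(=C/c1cccc(OC)c1)c1cc(OC)c(OC)c(OC)c1`, in this assay gives 1.3 uM.
Compound 3, `COc1ccc(/C=C\c2cc(OC)c(OC(C)=O)c(OC)c2)cc1`, in this assay gives 21.5 uM.

Of the three measured compounds, compound 1 alone yields no number: its entry is a limit of the assay, and it sits at the limit of > 25 uM in this assay, at which 1 of the 3 values shown sits. Compounds 2 and 3 both give numbers, and the two values show compound 2 at a smaller concentration than compound 3.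

Compound 4, `COc1cc(/C=C/c2ccc(SC)cc2)cc(OC)c1OC`, differs from compound 1 in one place: methylsulfanyl in place of tert-butyl on an aromatic carbon. Going by the values given here, no measured pair in this set follows the same change, so the step from compound 1 to compound 4 can only be anticipated, not read off. The expected step of an at least 2.5-fold lower number from compound 1 to compound 4 (0.39 log units; beyond the scatter) is toward smaller concentrations, by a margin beyond the usual scatter, since compound 1 starts at the limit of > 25 uM in this assay, at which 1 of the 3 values shown sits, and any measured number for compound 4 would lie on the lower side. Compound 4 is estimated at 10 uM, with a range from 2 uM to 30 uM.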

Compound 4, concentration for half-maximal effect: 4.7 uM
Estimate against measurement, compound 4: 2.1-fold (0.33 log units) above, within the range that was stated.
By their numbers in this assay, from the lowest: compound 2; then compound 4; then compound 3. At a limit, above all of these: compound 1.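

In this assay, methylsulfanyl in place of tert-butyl on an aromatic carbon gives an at least 5.3-fold lower number from compound 1 to compound 4 (0.72 log units; beyond the scatter), which shows that a change at this position, para to a large group, can move the read-out beyond the scatter. Going by these compounds alone, the earlier compounds held no pair differing in one place, so this is the first step that can be read, and it gives the core of compound 1 a measured number. Compound 1 itself stands at a limit and not at a number: the limit of > 25 uM in this assay, at which 1 of the 4 values shown sits.

The compounds shown leave open whether an amine, a hydroxyl group or a longer sulfur-bearing chain at this position would give a number nearer that of compound 4 or stay at a limit like compound 1. On these data alone, what lies behind the step also stays open, as does whether the same change would act alike on the cores of compound 2 and compound 3.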